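The compounds below may be only part of what the source reports. "The series", "measured", "known", "first", "only" and "open" are said of these compounds alone.

Going by the values given here, compound 1 `C[C@H](NC(=O)c1cccc(F)c1)c1ccc(NC(=O)N2CC(c3cccnc3)C2)cc1` is the stronger of the two compounds measured so far in a functional assay on COR-L23 cells (Homo sapiens) for antiproliferative activity, read by CellTiter-Glo, with a stated time of 72 h (a lower number here means a stronger inhibitor, a higher number a weaker inhibitor), where compound 1 gives 10 nM. Among the compounds with values here, its only measured neighbour is compound 2 `CCC(=O)N[C@@H](C)c1ccc(NC(=O)N2CC(c3cccnc3)C2)cc1`, which in this assay gives 120 nM; the step of a 12-fold higher number from compound 1 to compound 2 (1.08 log units; beyond the scatter) comes from replacing the 3-fluorophenyl on the carbonyl carbon with an ethyl group, and it is the only measured step available.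

Compound 3 `C[C@H](NC(=O)c1cccc(F)c1)c1ccc(NC(=O)N2CC(c3ccc(N)nc3)C2)cc1` keeps the whole amide side of compound 1 and changes the ring at the other end instead: amino in place of hydrogen on an aromatic carbon. Within the data shown here, the measured step concerns a different part of the molecule, so it says nothing direct about this change; there is no measured example of altering the six-membered aromatic ring with 1 nitrogen. Without such a precedent, the expectation for compound 3 is a step of no change at the digits printed from compound 1 to compound 3 (within the scatter), that is, no change beyond the usual scatter. On that basis compound 3 is estimated to give 10 nM in this assay, with a plausible range from 3 nM to 40 nM.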

Compound 3, half-maximal inhibitory concentration: 27 nM
For compound 3 the middle estimate is 2.7-fold (0.43 log units) below the measured one, within the range that was stated.
By their numbers in this assay, from the lowest: compound 1; then compound 3; then compound 2.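

In this assay, going by these compounds alone, the step of a 2.7-fold higher number from compound 1 to compound 3 (0.43 log units; beyond the scatter) is the first measured evidence from the ring end of the molecule, and it shows that this position is sensitive to substitution: adding an amino group next to the ring nitrogen, para to a large group, gives a modest but real change. That step is clearly smaller than the step of a 12-fold higher number from compound 1 to compound 2 (1.08 log units; beyond the scatter) on the amide side, so among the changes shown, swapping the 3-fluorophenyl for an ethyl group costs far more than adding this amino group, and compound 3 still gives 27 nM. Nothing available explains why the amino group raises the number, and no supporting measurement bears on the result.

The compounds shown leave open whether the step belongs to the amino group in particular or to any substituent on this carbon, which a methyl, a methoxy or a fluorine at the same place could help to separate. They also leave open whether the amino group would bring a similar step when paired with the ethyl amide of compound 2.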